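The compounds below may be only part of what the source reports. "The series", "measured", "known", "first", "only" and "open" are said of these compounds alone.

Measured so far:
- compound 1, `O=C(CCl)Nc1cccc(-c2nc3ccccc3s2)c1`: 1000 nM
- compound 2, `O=C(Nc1cccc(-c2nc3ccccc3s2)c1)c1cccnc1Cl`: 520 nM

Within the data shown here, in a physicochemical assay for solubility, in phosphate buffer, measured as kinetic solubility, with a stated time of 18 h, at pH 7.4 (on this read-out lower numbers stand for lower solubility and higher numbers for higher solubility), compound 2 gives 520 nM, the lowest of the two numbers; its only neighbour is compound 1, and the step of a 1.9-fold lower number from compound 1 to compound 2 (0.28 log units; within the scatter) stays within the scatter, so the two cannot be told apart.

Compound 3, `O=C(Nc1cccc(-c2nc3ccccc3s2)c1)c1cc([N+](=O)[O-])cnc1Cl`, has not yet been measured. It differs from compound 2 in one place: nitro in place of hydrogen on an aromatic carbon, two atoms from the ring nitrogen, meta to a large group and para to a chloro group. Among the measured compounds shown here, no measured step involves a nitro group; the single step from compound 1 to compound 2 changed the carbonyl substituent and lay within the scatter, so it gives no guidance here. The estimate therefore rests on the starting number alone, with a modest downward lean. The expected step is a 2.1-fold lower number from compound 2 to compound 3 (0.32 log units; beyond the scatter). Compound 3 is estimated at 250 nM, with a range from 80 nM to 800 nM.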

Compound 3, solubility: 450 nM
For compound 3 the middle estimate is 1.8-fold (0.26 log units) below the measured one, and the stated range covers the measured number.
By their numbers in this assay, from the lowest: compounds 3, 2 and 1 (each within the scatter of the next, the first and the last beyond it).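

In this assay, placing a nitro group on the aromatic carbon two atoms from the ring nitrogen and para to a chloro group gives a 1.2-fold lower number from compound 2 to compound 3 (0.06 log units; within the scatter), so the two compounds cannot be told apart. Among these compounds, this is the first look at this ring position, since the earlier step changed only the group on the carbonyl carbon. It shows that three extra heavy atoms, with two hydrogen-bond acceptors, can enter here without a difference that stands clear of the usual scatter, though no measurement shown explains this result.

Going by these compounds, whether an amine or a carboxylic acid at the same position would also stay within the scatter remains open. One substituent at one position also cannot show whether the number follows any trend across this ring.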